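The source may hold more compounds than are shown below. What is called first, only, known or untested is meant among the compounds shown, and "the series" means these compounds.

Measured so far:
- compound 1 `CCOC(=O)c1c(-c2cccc(Cl)c2)[nH]c2cc(OC)c(Cl)cc2c1=O`: > 21500 nM, a limit of the assay rather than a number
- compound 2 `CCOC(=O)c1c(-c2cccc(Br)c2)[nH]c2cc(OC)c(Cl)cc2c1=O`: > 21500 nM, likewise a limit
- compound 3 `CCOC(=O)c1c(-c2cccc(Cl)c2)[nH]c2cc(OC)c(F)cc2c1=O`: > 21500 nM, likewise a limit

All three values come from an ADME assay on HepG2 cells (Homo sapiens) for cytotoxicity, read by luminescence, with a stated time of 72 h; a higher number here means that more compound is needed for the effect, a lower number that less compound is needed. Compound 2 differs from compound 1 by bromo in place of chloro on an aromatic carbon; the corresponding step is a step that the two limits leave unreadable from compound 1 to compound 2. Compound 3 differs from compound 1 in the core, by fluoro in place of chloro on an aromatic carbon; that step is a step that the two limits leave unreadable from compound 1 to compound 3. Neither step can be sized, since both ends sit at the limit of > 21500 nM in this assay, at which 3 of the 3 values shown sit.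

Compound 4 `CCOC(=O)c1c(-c2cccc(Br)c2)[nH]c2cc(OC)c(F)cc2c1=O` has not yet been measured in this assay. It differs from compound 3 by bromo in place of chloro on an aromatic carbon, which is the same change as that from compound 1 to compound 2, in the same place and with the same surroundings.

For compound 4 in this assay the expected step is a step that the limit leaves unreadable from compound 3 to compound 4, an expectation that rests on the fact that the same change left compound 1 and compound 2 both at the limit of > 21500 nM in this assay, at which 3 of the 3 values shown sit, and that compound 3 also sits at that limit. Compound 4 is accordingly estimated at 35000 nM, most likely reported again only as a limit, with a plausible range from 21500 nM to 150000 nM.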

Compound 4, half-maximal effective concentration: > 21500 nM
Compound 4: a limit, no number (the forecaster's own chance of this, stated with the estimate: 90%); the middle value is on the limit's open side.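

In this assay no step can be read from compound 3 to compound 4 or from compound 2 to compound 4, since both ends of each pair are limits rather than numbers: the limit of > 21500 nM in this assay, at which 4 of the 4 values shown sit.

The compounds shown leave open whether bromo in place of chloro, or fluoro in place of chloro, changes the half-maximal effective concentration at all in this assay, and where any of the four compounds would give an actual number.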